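Swapping Chloro for Bromo on an Aryl Sulfonamide Antagonist

A few compounds are considered here, and "the series" means these few. Any claim that something is new, unique, unknown or untested is made for them only; others in the source may bear on it.

Measured so far:
Compound 1 `CC1CCN(c2nc(C(F)(F)F)ccc2CNC(=O)C(C)c2ccc(NS(C)(=O)=O)cc2)CC1` — 1.2 nM
Compound 2 `CC1CCN(c2nc(C(F)(F)F)ccc2CNC(=O)C(C)c2ccc(NS(C)(=O)=O)c(Cl)c2)CC1` — 2.3 nM

The two compounds share one core and differ at a single aromatic carbon. Both were tested in an assay on cells for antagonist activity at transient receptor potential cation channel subfamily V member 1 (Homo sapiens), read by FLIPR and calcium flux, with a stated time of 15 min; on this read-out higher numbers stand for weaker inhibition and lower numbers for stronger inhibition. Compound 1 gives 1.2 nM; compound 2 gives 2.3 nM. The step from hydrogen to chlorine, a 1.9-fold higher number from compound 1 to compound 2 (0.28 log units; within the scatter), is small enough to be noise. Compound 2 therefore has the higher of the two numbers, but the gap to compound 1 does not separate the two beyond the scatter, so neither can be called stronger.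

Compound 3 `CC1CCN(c2nc(C(F)(F)F)ccc2CNC(=O)C(C)c2ccc(NS(C)(=O)=O)c(Br)c2)CC1` continues from compound 2 with bromo in place of chloro on an aromatic carbon, placed on an aromatic carbon of a six-membered aromatic ring of carbon only, ortho to a methanesulfonamido group and meta to a large group. For the measured compounds named here, no measured pair covers a chlorine-to-bromine swap; the only step available, from compound 1 to compound 2, shows a halogen entering this position with little effect. A change of one halogen for its larger neighbour is expected to move the number even less, giving an estimated 1.1-fold higher number from compound 2 to compound 3 (0.04 log units; within the scatter). For compound 3 the expected value is 2.5 nM, within 1 nM to 6 nM.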

Compound 3, inhibition constant: 3.2 nM
Compound 3: the middle estimate sits 1.3-fold (0.11 log units) below what was measured; low and high end bracket the measured number.
By their numbers in this assay, from the lowest: compounds 1, 2 and 3 (each within the scatter of the next, the first and the last beyond it).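

In this assay, the exchange of chloro for bromo gives a 1.4-fold higher number from compound 2 to compound 3 (0.14 log units; within the scatter) and so leaves these two halogens indistinguishable on this aromatic carbon. For the compounds shown here, the new information comes from the comparison with hydrogen: bromo in its place gives a 2.7-fold higher number from compound 1 to compound 3 (0.43 log units; beyond the scatter) and is the first step at this position to clear the scatter, so a halogen here can come at a modest cost in inhibition, even though chloro alone could not be told apart from hydrogen or from bromo. No measurement at hand explains this step.

The three compounds cannot show whether the modest loss belongs to halogens in particular or would also follow other groups on this carbon, such as fluoro, methyl, methoxy or nitrile. They also leave open whether an amine or a hydroxyl group here would keep the number close to that of compound 1, and whether the same exchanges would give similar steps with a different group in place of the methanesulfonamido group.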